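A few compounds are considered here, and "the series" means these few. Any claim that something is new, unique, unknown or untested is made for them only; others in the source may bear on it.

Measured so far in an assay on membranes from liver for displacement of a labelled ligand from Sigma intracellular receptor 2 (Rattus norvegicus), read by scintillation counting, with a stated time of 120 min, in the presence of a further agent that is not named here; a higher number here means a weaker inhibitor, a lower number a stronger inhibitor:
compound 1 `c1ccc(CCCCNC2CCc3ccsc3CC2)cc1` gives 5.7 nM;
compound 2 `CN(CCCCc1ccccc1)C1CCc2ccsc2CC1` gives 12 nM;
compound 3 `OCc1cc2c(s1)CCC(NCCCc1ccccc1)CC2` gives 30 nM.

Compound 2 differs from compound 1 by methyl in place of hydrogen on an amine nitrogen. In this assay this change gave a 2.1-fold higher number from compound 1 to compound 2 (0.32 log units; beyond the scatter). Compound 4 `CN(CCCc1ccccc1)C1CCc2cc(CO)sc2CC1` is not yet measured; it differs from compound 3 by methyl in place of hydrogen on an amine nitrogen, the same change made at a place described in the same words. The difference between the core of compound 1 and the core of compound 3 is not broken down here; compound 3 gives the highest number of the three measured. Since the change is the same and the place is the same, the step from compound 3 to compound 4 in this assay is expected to be about a 2.0-fold higher number from compound 3 to compound 4 (0.30 log units; within the scatter), resting on the earlier step of a 2.1-fold higher number from compound 1 to compound 2 (0.32 log units; beyond the scatter). Compound 4 is accordingly estimated at 60 nM, expected to fall between 25 nM and 150 nM.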

Compound 4, inhibition constant: 21 nM
Estimate against measurement, compound 4: 2.9-fold (0.46 log units) above; the measured number lies below the stated range.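

In this assay, methyl in place of hydrogen on the amine nitrogen gave a 1.4-fold lower number from compound 3 to compound 4 (0.15 log units; within the scatter). The change therefore does not carry over as a fixed step between these cores, and its size on one core does not predict its size on the other: the same change on two cores in this assay, a 2.1-fold higher number (0.32 log units; beyond the scatter) from compound 1 to compound 2 and a 1.4-fold lower number (0.15 log units; within the scatter) from compound 3 to compound 4, 3.0-fold (0.48 log units) apart, beyond the scatter of two such steps

For the compounds shown here, this rests on only two pairs and does not show which difference between the cores goes with the gap, or why the steps differ.

The compounds shown do not separate the hydroxymethyl group from the chain length as the source of the gap. Also open, as far as these compounds go, is how ethyl on the amine nitrogen, or a carboxylic acid in place of the hydroxymethyl group, would behave on either core.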